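The source may report more compounds than this note shows. Statements on the series, on what has been measured and on what is new or still open speak of the compounds shown alone.

Measured so far:

Compound 1 `C[C@H]1C[C@H](c2nc(-c3ccc4ccccc4n3)no2)CCN1C(=O)Nc1ccccc1Cl` — in a functional assay on Shh Light II cells (Mus musculus) for inhibition, read by a luciferase reporter (a higher number here means a weaker inhibitor, a lower number a stronger inhibitor), compound 1 gives 900 nM
Compound 2 `O=C(CC1CCCCCC1)N1CCC(c2nc(-c3ccc4ccccc4n3)no2)CC1` — in this assay compound 2 gives 840 nM
Compound 3 `O=C(NC1CCCCC1)N1CCN(c2nc(-c3ccc4ccccc4n3)no2)CC1` — in this assay compound 3 gives 53 nM

All three share the same core; they differ in the group attached to the carbonyl carbon on the ring nitrogen. On the numbers shown, compound 2 stands second highest of the three: its value and that of compound 1 lie within the usual scatter of each other, while compound 3 sits well below both, beyond that scatter.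

Compound 4 `O=C(NCC1CCC1)N1CCC(c2nc(-c3ccc4ccccc4n3)no2)CC1` has not yet been measured. It follows from compound 2 by one change ((cyclobutylmethyl)amino in place of cycloheptylmethyl on a carbonyl carbon). Within the data shown here, compound 3, which also carries an amino group on its carbonyl carbon, gives the lowest number here, but it also differs in its ring, so no direct step between measured compounds tells how much this change alone is worth. A moderate step downward, beyond the scatter, is expected in this assay, with wide uncertainty.

The estimated step from compound 2 to compound 4 in this assay is a 2.8-fold lower number from compound 2 to compound 4 (0.45 log units; beyond the scatter), an expectation resting on the low value of compound 3 53 nM. Compound 4 is therefore estimated at 300 nM in this assay, within a range from 80 nM to 1100 nM.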

Compound 4, half-maximal inhibitory concentration: 410 nM
Beside the measured number, compound 4's estimate is 1.4-fold (0.14 log units) below it, and the stated range covers the measured number.
By their numbers in this assay, from the lowest: compound 3; then compound 4; then compounds 2 and 1 (each within the scatter of the next).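

In this assay, among these compounds, putting (cyclobutylmethyl)amino in place of cycloheptylmethyl on the carbonyl carbon gives a 2.0-fold lower number from compound 2 to compound 4 (0.31 log units; beyond the scatter), a modest step and the first direct reading of a change at this position with the rest of the molecule held constant. The change alters several things at once: the ring shrinks from seven members to four, the group loses heavy atoms, and it gains a nitrogen and a hydrogen-bond donor, so this one step cannot assign the gain to any of them. Nothing measured here explains the step.

On these data alone, whether the nitrogen or the ring size matters more remains open, and (cycloheptylmethyl)amino or cyclobutylmethyl on the same carbonyl carbon would separate the two. An open-chain butylamino group would show whether a ring is needed here at all.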